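Swapping the triazolylthio group for an aminothiadiazolylthio group

This account rests on a few compounds, and the source may have more. Where it says the series, first, only, none or still open, it means among the compounds named here.

Measured compounds:
compound 1 `COc1cc(-c2nc(CO[C@@H]3O[C@H](CSc4ncn[nH]4)[C@H]4OC5(CCCC5)O[C@@H]34)no2)cc(OC)c1OC` 34000 nM
compound 2 `CC1(C)O[C@H]2[C@H](OCc3noc(-c4ccc([N+](=O)[O-])cc4)n3)O[C@H](CSc3ncn[nH]3)[C@H]2O1` > 100000 nM
compound 3 `Nc1nnc(SC[C@H]2O[C@@H](OCc3noc(-c4ccc([N+](=O)[O-])cc4)n3)[C@@H]3OC4(CCCC4)O[C@@H]32)s1` 26000 nM

Compound 2 gives only a limit in a functional assay on HBL-100 cells (Homo sapiens) for antiproliferative activity, read by sulforhodamine B assay, with a stated time of 48 h (on this read-out higher numbers stand for weaker inhibition of growth and lower numbers for stronger inhibition of growth), namely > 100000 nM; it sits at the limit of > 100000 nM in this assay, at which 1 of the 3 values shown sits. Among the compounds with values here, compound 1 and compound 3 give numbers, with no step recorded between them. Within the data shown here, compound 4 `CC1(C)O[C@H]2[C@H](OCc3noc(-c4ccc([N+](=O)[O-])cc4)n3)O[C@H](CSc3nnc(N)s3)[C@H]2O1` carries 5-amino-1,3,4-thiadiazol-2-yl in place of 1H-1,2,4-triazol-5-yl on a sulfur; no measured pair shows this change alone. The writer expects compound 4 to move from the limit to a measurable value, as a step of an at least 2.0-fold lower number from compound 2 to compound 4 (0.30 log units; that floor lies within the scatter) in this assay, though a further limit cannot be excluded. Compound 4 is therefore estimated at 50000 nM, with a range from 15000 nM to 200000 nM, the measured value being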

Compound 4, concentration for 50% growth inhibition: > 100000 nM
Compound 4 ended at the assay's limit (the forecaster's own chance of this, stated with the estimate: 40%); middle value at least 2.0-fold (0.30 log units) away from the limit.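

Within the data shown here, compound 2 and compound 4 both end at a limit, so no step between them can be read: the limit of > 100000 nM in this assay, at which 2 of the 4 values shown sit. Going by these compounds, whether 5-amino-1,3,4-thiadiazol-2-yl in place of 1H-1,2,4-triazol-5-yl on a sulfur changes growth inhibition at all stays open.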